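Methyl on nitrogen: an amide pair and an aniline pair

The compounds below may be only part of what the source reports. "The series", "measured", "known", "first", "only" and "open" are said of these compounds alone.

Compound 1 `CC(C)c1onc(-c2c(Cl)cccc2Cl)c1COc1ccc(N(C)C(=O)c2ccc(C(=O)O)cc2)c(C(F)(F)F)n1` and compound 2 `CC(C)c1onc(-c2c(Cl)cccc2Cl)c1COc1ccc(NC(=O)c2ccc(C(=O)O)cc2)c(C(F)(F)F)n1` share one core and differ by methyl in place of hydrogen on an amide-type nitrogen. In a functional assay on HEK293 cells for agonist activity at Bile acid receptor (Homo sapiens) (a higher number here means that more compound is needed for the effect, a lower number that less compound is needed), compound 2 gives 474 nM and compound 1 gives 316 nM; the step of a 1.5-fold lower number from compound 2 to compound 1 (0.18 log units; within the scatter) lies within the scatter. Compound 3 `CC(Nc1ccc(C(=O)O)cc1)c1ccc(OCc2c(-c3c(Cl)cccc3Cl)noc2C2CC2)nc1C(F)(F)F` carries a different core; the difference between the two cores is not broken down here. In this assay compound 3 gives 333 nM, within the scatter of compound 1 and of compound 2. Compound 4 `CC(c1ccc(OCc2c(-c3c(Cl)cccc3Cl)noc2C2CC2)nc1C(F)(F)F)N(C)c1ccc(C(=O)O)cc1` differs from compound 3 by methyl in place of hydrogen on a nitrogen on an aromatic ring. This is the same kind of change as in the measured pair, but the place differs: there the nitrogen's other neighbours are aromatic carbon and carbonyl carbon, here aromatic carbon and saturated chain carbon. For compound 4 a step of a 1.3-fold lower number from compound 3 to compound 4 (0.11 log units; within the scatter) is expected, because a 1.5-fold lower number from compound 2 to compound 1 (0.18 log units; within the scatter) stayed within the scatter. The estimate for compound 4 in this assay is 260 nM, with a range from 100 nM to 700 nM.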

Compound 4, half-maximal effective concentration: 208 nM
Compound 4: middle estimate off by 1.3-fold (0.10 log units), on the high side; measured number inside the range.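

In this assay the step of a 1.6-fold lower number from compound 3 to compound 4 (0.20 log units; within the scatter) stays small, as it does on the amide-type nitrogen of the other core, and the two steps do not differ: the same change on two cores in this assay, a 1.5-fold lower number (0.18 log units; within the scatter) from compound 2 to compound 1 and a 1.6-fold lower number (0.20 log units; within the scatter) from compound 3 to compound 4, 1.1-fold (0.03 log units) apart, within the scatter of two such steps. On these two cores, then, methyl in place of hydrogen carries over with no step beyond the scatter, whether the nitrogen bears a carbonyl carbon or a saturated chain carbon. This does not show a real effect of the methyl on either core, and two cores say nothing about a third.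

Still open, as far as these compounds go, is whether a longer chain on this nitrogen, such as ethyl or propyl, moves the number beyond the scatter. From the compounds shown here alone, an acetyl group on the same nitrogen is equally open.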